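This account rests on a few compounds, and the source may have more. Where it says the series, first, only, none or still open, it means among the compounds named here.

Measured so far in a physicochemical assay for lipophilicity, using the shake flask method, in phosphate buffer, measured as octanol-water partition, with a stated time of 2 h, at pH 7.4, tested at 1 uM; on this read-out lower numbers stand for lower lipophilicity and higher numbers for higher lipophilicity:
- compound 1 `O=[N+]([O-])c1ccc2c(ccn2-c2ccc(O[C@H]3O[C@H](CO)[C@@H](O)[C@H](O)[C@@H]3O)c(Cl)c2)c1`: 1.8
- compound 2 `COc1ccc2c(ccn2-c2ccc(O[C@H]3O[C@H](CO)[C@@H](O)[C@H](O)[C@@H]3O)c(Cl)c2)c1`: 3
- compound 3 `OC[C@H]1O[C@H](Oc2ccc(-n3ccc4c(OCc5ccccc5)cccc43)cc2Cl)[C@@H](O)[C@@H](O)[C@@H]1O`: 2.7

Compound 1 has the lowest number of the three, and both compound 3 at 2.7 and compound 2 at 3 lie beyond the scatter above it.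

Compound 4 `O=[N+]([O-])c1ccc2c(ccn2-c2ccc(O[C@H]3O[C@H](CO)[C@@H](O)[C@H](O)[C@@H]3O)c(F)c2)c1` keeps the core of compound 1 and carries a single change: fluoro in place of chloro on an aromatic carbon. This is fluoro in place of chloro on an aromatic carbon, ortho to a large group and meta to a large group.

Among the measured compounds shown here, the one measured step, a number 1.20 log units higher from compound 1 to compound 2 (beyond the scatter), is large, but it is methoxy in place of nitro and leaves the chloro untouched. It therefore shows only how far one exchange can move this assay in this series. For the measured compounds named here, no measured pair exchanges the chloro, so the expectation rests on the structural change alone: a much smaller step than that one, towards a lower number.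

The expected step is a number 0.40 log units lower from compound 1 to compound 4 (beyond the scatter).

Compound 4 is estimated at 1.4, with an expected range from 1 to 1.8.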

Compound 4, distribution coefficient: 1.9
Compound 4: the middle estimate sits 0.50 log units below what was measured, outside the stated range (above it).
By their numbers in this assay, from the lowest: compounds 1 and 4 (each within the scatter of the next); then compounds 3 and 2 (each within the scatter of the next).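

In this assay, among the compounds shown here, the first measured exchange at this position, fluoro in place of chloro on an aromatic carbon, ortho to a large group and meta to a large group, gives a number 0.10 log units higher from compound 1 to compound 4 (within the scatter). With the nitro group in place, the two halogens therefore cannot be told apart on this read-out, whereas methoxy in place of nitro gives a number 1.20 log units higher from compound 1 to compound 2 (beyond the scatter). Nothing on hand offers an explanation for this result.

Still open, from the compounds shown here alone, is whether fluoro and chloro also stay within the scatter of each other on the core of compound 2, which carries methoxy in place of nitro. Also open, going by these compounds, is how this assay would read with an amine or a carboxylic acid at this position.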